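The source may hold more compounds than are shown below. What is called first, only, known or untested is meant among the compounds shown, and "the series" means these compounds.

Working notes, cytotoxicity series. Compound 3 `COc1cc(OC)c2c(=O)c(OCC(=O)N/N=C/c3ccco3)c(-c3cc(OC)c(OC)c(OC)c3)oc2c1` gives the lowest of the three numbers in a functional assay on SGC-7901 cells (Homo sapiens) for cytotoxicity, read by MTT assay, with a stated time of 38 h (a lower number here means a stronger inhibitor, a higher number a weaker inhibitor), at 5720 nM. Compound 1 `COc1cc(OC)c2c(=O)c(OCC(=O)N/N=C/c3ccc[nH]3)c(-c3cc(OC)c(OC)c(OC)c3)oc2c1` sits nearest, at 8730 nM, with a 1.5-fold lower number from compound 1 to compound 3 (0.18 log units; within the scatter). Compound 2 `COc1cc(OC)c2c(=O)c(OCCCCN3CCCC3)c(-c3cc(OC)c(OC)c(OC)c3)oc2c1` sits furthest, at 26800 nM, with a 4.7-fold lower number from compound 2 to compound 3 (0.67 log units; beyond the scatter). Compound 4 `CCN(CC)CCCOc1c(-c2cc(OC)c(OC)c(OC)c2)oc2cc(OC)cc(OC)c2c1=O` is not yet measured. Against compound 3 it differs in one place: a group of 7 heavy atoms (6 carbon, 1 nitrogen; no ring) in place of a group of 10 heavy atoms (6 carbon, 2 nitrogen, 2 oxygen; one five-membered aromatic ring with 1 hetero atom), on a saturated chain carbon bound to an oxygen on an aromatic ring. Among the compounds with values here, two steps bear on this exchange of a hydrazone-bearing group for an amine-bearing chain: a 3.1-fold higher number from compound 1 to compound 2 (0.49 log units; beyond the scatter) and, read in reverse, the step between compound 2 and compound 3. Both point to a higher number in this assay for compound 4, beyond the scatter but modest. The expected step is therefore a 3.5-fold higher number from compound 3 to compound 4 (0.54 log units; beyond the scatter), and compound 4 is estimated at 20000 nM, with a range from 8000 nM to 50000 nM.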

Compound 4, half-maximal inhibitory concentration: 56900 nM
Beside the measured number, compound 4's estimate is 2.8-fold (0.45 log units) below it, and the stated range ends below it.
By their numbers in this assay, from the lowest: compounds 3 and 1 (each within the scatter of the next); then compound 2; then compound 4.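

In this assay, exchanging the hydrazone-bearing groups for the 2-(diethylamino)ethyl chain gives larger steps than the pyrrolidine-bearing chain of compound 2 did: a 9.9-fold higher number from compound 3 to compound 4 (1.00 log units; beyond the scatter) and a 6.5-fold higher number from compound 1 to compound 4 (0.81 log units; beyond the scatter). The amine end of the chain also matters at this position, with diethylamino in place of (pyrrolidin-1-yl)methyl giving a 2.1-fold higher number from compound 2 to compound 4 (0.33 log units; beyond the scatter). No supporting data explain these differences. The compounds shown leave open whether a morpholine or piperazine at the chain end, or a longer chain, would lower the number.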